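The source may hold more compounds than are shown below. What is called first, only, known or untested is meant among the compounds shown, and "the series" means these compounds.

Measured so far in an in vitro ADME assay on microsomes from liver (Rattus norvegicus) for metabolic stability; a lower number here means slower removal, a higher number faster removal of the compound:
compound 1, `CC[C@H](C)[C@@H]1C(=O)N[C@H](C2Cc3ccccc3C2)C(=O)N1[C@@H](C(=O)N(C)C)c1ccc(C)[n+]([O-])c1`: 1 mL.min-1.g-1
compound 2, `CC[C@H](C)[C@@H]1C(=O)N[C@H](C2Cc3ccccc3C2)C(=O)N1[C@@H](C(=O)NC)c1cc(C)cnc1C`: 1 mL.min-1.g-1
compound 3, `CC[C@H](C)[C@@H]1C(=O)N[C@H](C2Cc3ccccc3C2)C(=O)N1[C@@H](C(=O)N(C)C)c1cnc(C)cc1C`: 1 mL.min-1.g-1

Compound 3 stands level with compound 1 and compound 2 in this assay; all three read the same at the digits given, and no ordering among them can be drawn. For the measured compounds named here, the single step measured, no change at the digits printed from compound 1 to compound 3 (within the scatter), was flat: exchanging one six-membered aromatic ring for the other on the saturated chain carbon left the reading where it was.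

Compound 4, `CC[C@H](C)[C@@H]1C(=O)N[C@H](C2Cc3ccccc3C2)C(=O)N1[C@@H](C(=O)NC)c1cnc(C)cc1C`, keeps the core and aromatic ring of compound 3 and differs only at the amide: hydrogen in place of methyl on an amide-type nitrogen. Going by the values given here, no step from a dimethylcarbamoyl to a methylcarbamoyl compound has been measured directly. Among the compounds with values here, compound 2, which carries a methylcarbamoyl group on its own aromatic ring, gives 1 mL.min-1.g-1, the same figure as the dimethylcarbamoyl compound 3, so the two amide forms have not separated in this assay so far.

Within the data shown here, with every measured value at one level and the only measured step flat, the expected step is no change at the digits printed from compound 3 to compound 4 (within the scatter), nothing beyond the scatter. Compound 4 is estimated at 1 mL.min-1.g-1, with a range from 0.5 mL.min-1.g-1 to 2 mL.min-1.g-1.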

Compound 4, intrinsic clearance in microsomes: 1 mL.min-1.g-1
Compound 4: the middle estimate sits on the measured number at the digits printed; the range from low to high includes it.
By their numbers in this assay, from the lowest: compounds 1, 2, 3 and 4 (each within the scatter of the next).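

In this assay the amide position now has a direct matched step: hydrogen in place of methyl on the amide-type nitrogen, which turns dimethylcarbamoyl into methylcarbamoyl, gives no change at the digits printed from compound 3 to compound 4 (within the scatter) on an otherwise unchanged structure, whereas the two amide forms could earlier be set side by side only on different aromatic rings. The methylcarbamoyl compounds also gain their first ring step, as 4,6-dimethylpyridin-3-yl in place of 2,5-dimethylpyridin-3-yl gives no change at the digits printed from compound 2 to compound 4 (within the scatter) and so matches the flat ring step already seen among the dimethylcarbamoyl compounds. Nothing available explains why either change leaves the reading flat.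

The compounds shown leave open whether a primary carboxamide, an ethyl group on the amide nitrogen or a carboxylic acid at this place would shift the reading from the level shared so far. They also leave open whether methylcarbamoyl would read the same on the aromatic ring of compound 1, or whether these flat steps hold once the shared core is changed.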